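A few compounds are considered here, and "the series" means these few. Any claim that something is new, unique, unknown or untested is made for them only; others in the source may bear on it.

Measured so far:
compound 1, `CC(=O)NC1=CS(=O)(=O)O[C@@]12[C@@H](CO[Si](C)(C)C(C)(C)C)O[C@@H](n1cc(C)c(=O)n(C)c1=O)[C@@H]2O[Si](C)(C)C(C)(C)C`: 10700 nM
compound 2, `Cc1cn([C@@H]2O[C@H](CO[Si](C)(C)C(C)(C)C)[C@@]3(OS(=O)(=O)C=C3NC(=O)c3ccccc3)[C@H]2O[Si](C)(C)C(C)(C)C)c(=O)n(C)c1=O`: 4900 nM

In a functional assay on MT4 cells (Homo sapiens) (a higher number here means that more compound is tolerated, a lower number that less compound is tolerated), compound 1 stands highest of the two numbers; the nearest is compound 2, reached by a 2.2-fold lower number from compound 1 to compound 2 (0.34 log units; beyond the scatter). Compound 3, `Cc1cn([C@@H]2O[C@H](CO[Si](C)(C)C(C)(C)C)[C@@]3(OS(=O)(=O)C=C3NCCC(N)=O)[C@H]2O[Si](C)(C)C(C)(C)C)c(=O)n(C)c1=O`, differs from compound 1 by 2-carbamoylethyl in place of acetyl on an amine nitrogen. For the measured compounds named here, the only measured step, phenyl in place of methyl on a carbonyl carbon, is a different kind of change and gives no direct guide, so a small step in either direction or none beyond the scatter is expected in this assay. For compound 3 the estimate is 9000 nM, range 4000 nM to 25000 nM, which means an expected 1.2-fold lower number from compound 1 to compound 3 (0.08 log units; within the scatter).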

Compound 3, half-maximal cytotoxic concentration: 20000 nM
Beside the measured number, compound 3's estimate is 2.2-fold (0.35 log units) below it, within the range that was stated.
By their numbers in this assay, from the lowest: compound 2; then compounds 1 and 3 (each within the scatter of the next).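

In this assay, 2-carbamoylethyl in place of acetyl on the amine nitrogen gives a 1.9-fold higher number from compound 1 to compound 3 (0.27 log units; within the scatter), so this position takes a chain with an amide hydrogen without a step beyond the scatter. Against benzoyl the same chain gives a 4.1-fold higher number from compound 2 to compound 3 (0.61 log units; beyond the scatter), which leaves compound 2 as the one compound set apart from the other two in this assay. No measured data bear on the reason for these steps.

Going by these compounds, whether a carboxylic acid, a free amine or a longer chain on that nitrogen would stay within the scatter of compound 1 remains open.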